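Sulfur in Place of Selenium: Expecting Little Change

A few compounds are considered here, and "the series" means these few. Any claim that something is new, unique, unknown or untested is made for them only; others in the source may bear on it.

Compound 1 `COc1ccc(CNc2nc([Se]C)nc3ccccc23)cc1` was tested in an ADME assay on BEAS-2B cells (Homo sapiens) for cytotoxicity, read by MTT assay, with a stated time of 72 h; a higher number here means a weaker inhibitor of growth, a lower number a stronger inhibitor of growth. In this assay compound 1 gives > 100000 nM, which is a limit of the assay and not a number. Compound 1 therefore sits at the limit of > 100000 nM in this assay, at which 1 of the 2 values shown sits, so where it truly stands is known only as a range. Compound 2 `C[Se]c1nc(NCc2ccccc2)c2ccccc2n1` carries a hydrogen in place of methoxy on an aromatic carbon, and in this assay compound 2 gives 37000 nM. That measured step, an at least 2.7-fold lower number from compound 1 to compound 2 (0.43 log units; beyond the scatter), concerns a different part of the molecule from the change considered here.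

Compound 3 `COc1ccc(CNc2nc(SC)nc3ccccc23)cc1` has not yet been measured. It differs from compound 1 by a group of 2 heavy atoms (1 carbon, 1 sulfur; no ring) in place of a group of 2 heavy atoms (1 carbon, 1 selenium; no ring), on an aromatic carbon. Among the compounds with values here, no measured step touches this kind of exchange: the only step recorded alters the methoxy group and leaves the group sitting between the two ring nitrogen atoms untouched. With nothing bearing on it, no step beyond the scatter is expected in this assay in either direction. The expected step is a number no higher from compound 1 to compound 3 (the limit leaves the size open). Compound 3 is therefore estimated at 100000 nM, within a range from 40000 nM to 300000 nM, and this assay may well again report only a limit.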

Compound 3, concentration for total growth inhibition: 96200 nM
For compound 3 the middle estimate is 1.0-fold (0.02 log units) above the measured one, within the range that was stated.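

In this assay, putting methylsulfanyl on the aromatic carbon between two ring nitrogen atoms, in place of the selenium-bearing group, gives an at least 1.0-fold lower number from compound 1 to compound 3 (0.01 log units; that floor lies within the scatter). The earlier compounds shown here showed nothing about this position, and here the sulfur-bearing compound 3 gives a true number of 96200 nM, so the position can now be read on at least one side of the exchange. Even so, the step is only a floor and its real size stays unknown, because compound 1 rests on a limit of the assay and not on a number: the limit of > 100000 nM in this assay, at which 1 of the 3 values shown sits.

The compounds shown leave open how the same exchange behaves on a partner whose selenium value is a true number, as in compound 2 at 37000 nM, where a sulfur-bearing counterpart with the same unsubstituted benzyl group would give a step with no limit in it. They also leave open whether a different group at this position, such as an amine or a longer chain like ethylsulfanyl, would shift the number in this assay beyond the usual scatter.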